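The compounds below may be only part of what the source reports. "The series", "measured", "known", "first", "only" and "open" are said of these compounds alone.

Measured compounds:
- compound 1 `Clc1ccc(-c2cc(-c3cccs3)nc(-c3ccccc3Cl)c2)o1` gives 16800 nM in a functional assay on DU-145 cells (Homo sapiens) for cytotoxicity, in the presence of a further agent that is not named here; on this read-out higher numbers stand for weaker inhibition and lower numbers for stronger inhibition
- compound 2 `Clc1ccc(-c2cc(-c3ccoc3)cc(-c3cccs3)n2)cc1` gives 21100 nM in this assay
- compound 3 `Clc1cccc(-c2cc(-c3ccc(Cl)o3)cc(-c3cccs3)n2)c1` gives 18100 nM in this assay

All three numbers sit close together. Compound 3 has the second highest of the three, with compound 1 nearest and compound 2 furthest, both within the scatter, so no order among them can be read. Compound 4 `Clc1ccc(-c2cc(-c3ccc(Cl)o3)cc(-c3cccs3)n2)cc1` is not yet measured; it differs from compound 3 in one place: 4-chlorophenyl in place of 3-chlorophenyl on an aromatic carbon. Within the data shown here, the one measured step that bears on this moves the chlorine around the same ring, a 1.1-fold higher number from compound 1 to compound 3 (0.03 log units; within the scatter), and it stayed within the scatter. Shifting the chlorine once more is therefore expected to bring no step beyond the scatter, a 1.0-fold lower number from compound 3 to compound 4 (0.00 log units; within the scatter). Compound 4 is estimated at 18000 nM, within 9000 nM to 36000 nM.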

Compound 4, half-maximal inhibitory concentration: 19200 nM
Beside the measured number, compound 4's estimate is 1.1-fold (0.03 log units) below it, within the range that was stated.
By their numbers in this assay, from the lowest: compounds 1, 3, 4 and 2 (each within the scatter of the next).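

Compound 4 completes the set of 2-chlorophenyl, 3-chlorophenyl and 4-chlorophenyl at this carbon next to the ring nitrogen, and moving the chlorine in this assay shows no step beyond the scatter (a 1.1-fold higher number from compound 3 to compound 4 (0.03 log units; within the scatter); a 1.1-fold higher number from compound 1 to compound 4 (0.06 log units; within the scatter)). Among these compounds, the first comparison at the other ring, 5-chlorofuran-2-yl in place of furan-3-yl, also stays within the scatter (a 1.1-fold lower number from compound 2 to compound 4 (0.04 log units; within the scatter)). No measurement offers an explanation for these small steps. On these data alone, whether an amine or a carboxylic acid on the phenyl ring would give a step beyond the scatter remains open.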